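The compounds below may be only part of what the source reports. "The series", "measured", "known", "first", "only" and "open" are said of these compounds alone.

Working notes on the series. Compound 1, `CCCc1ccc(C(=O)Nc2cc3nc(C4CCCCC4)[nH]c3cc2N(C)C)cc1`, in an ADME assay on Vero cells (Chlorocebus sabaeus) for cytotoxicity, read by resazurin assay, with a stated time of 3 days (a lower number here means a stronger inhibitor, a higher number a weaker inhibitor), gives > 100 ug/mL, which is a limit of the assay and not a number. Compound 3, `CCCN(CCC)c1cc2[nH]c(C3CCCCC3)nc2cc1NC(=O)OCc1ccccc1`, in this assay gives > 100 ug/mL, again a limit rather than a number. Compound 2, `CCCc1ccc(C(=O)Nc2cc3nc(C4CCCCC4)[nH]c3cc2N(CC)CC)cc1`, in this assay gives "not determined" (no result reported), so no number places it on this scale. The two other values shown in this assay both sit at the limit of > 100 ug/mL in this assay, at which 2 of the 3 values shown sit, and compound 2 can only be set beside them, not ranked against them. Compound 4, `CCCCNC(=O)Nc1cc2nc(C3CCCCC3)[nH]c2cc1N(CC)CC`, is the next compound to be measured in this assay. Compound 4 differs from compound 2 by butylamino in place of 4-propylphenyl on a carbonyl carbon. Within the data shown here, no step between measured compounds in this assay exists to draw on for the size of this change, and no number for compound 2 exists from which a step could be counted; the expectation rests on the two neighbours alone. Since both compound 1 and compound 3 sit at the limit of > 100 ug/mL in this assay, at which 2 of the 3 values shown sit, in this assay, no shift beyond the scatter is expected in either direction for compound 4, and a limit rather than a number is the likelier outcome. Compound 4 is expected to give about 100 ug/mL in this assay, within 50 ug/mL to 200 ug/mL.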

Compound 4, half-maximal inhibitory concentration: > 100 ug/mL
Compound 4: no number, only a limit; the forecaster's own chance of this, stated with the estimate: 70%; the middle value sits exactly at the limit.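

No new step can be read between compound 2 and compound 4: compound 2 carries no number in this assay. Compound 4 gives > 100 ug/mL, a limit and not a number. The compounds shown leave open whether butylamino in place of 4-propylphenyl changes anything in this assay, and how far any compound lies past the limit: the limit of > 100 ug/mL in this assay, at which 3 of the 4 values shown sit.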